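One Stereocentre Drawn, Oral Bioavailability Still Open

The source may hold more compounds than are shown below. What is called first, only, known or untested is meant among the compounds shown, and "the series" means these compounds.

Measured in an ADME assay on the whole organism for pharmacokinetics, with Mus musculus as the target, read by LC-MS, using cassette dosing, at a dose of 1 mg/kg by the oral route; on this read-out lower numbers stand for lower oral bioavailability and higher numbers for higher oral bioavailability:
Compound 1 `COc1cc(C(=O)N2CCC(NC(=O)c3ccccc3OC(F)(F)F)c3c2cnn3C(C)C)cnc1OC`: 25%
Compound 2 `COc1ccc(C(=O)N2CC[C@@H](NC(=O)c3ccccc3Cl)[C@@H](c3ccccc3)C2)cc1OC`: < 1%, a limit of the assay

For the measured compounds named here, compound 1, at 25%, holds the only actual number in this small set. The value of compound 2 is a limit and gives no number to compare.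

Compound 3 `COc1cc(C(=O)N2CC[C@H](NC(=O)c3ccccc3OC(F)(F)F)c3c2cnn3C(C)C)cnc1OC` has the same atoms and bonds as compound 1: the two compounds have the same atoms and bonds; at least one stereo element is drawn with a configuration in one of them and without one in the other: 1 of 1 stereo elements differ; a stereocentre at a saturated ring carbon is drawn without a configuration in compound 1 and S in compound 3. Going by the values given here, no measured step covers such a change, so compound 1 is the only anchor. No shift beyond the usual scatter is expected, in either direction, and the estimated change is no change at the digits printed from compound 1 to compound 3 (within the scatter). Compound 3 is expected at 25%, with an estimated range from 10% to 45%.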

Compound 3, oral bioavailability: 53%
For compound 3 the middle estimate is 28 percentage points below the measured one; the whole stated range lies below it.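

In this assay the step reads a number 28 percentage points higher from compound 1 to compound 3 (beyond the scatter) and lies beyond the scatter, so this saturated ring carbon matters even though no atom or bond changes. For the compounds shown here, it is the first step in this set that can be read at any position. Going by these compounds alone, the only difference the step can be traced to is this: the fact that one of compounds 1 and 3 is drawn with a defined configuration and the other without, at the place where they differ.

As far as these compounds go, the R configuration at this carbon remains open, so the two defined forms cannot be compared. Also open, from the compounds shown here alone, is whether the step would persist with an amine or a carboxylic acid on the shared core.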